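Cytotoxicity notes on a bridged amine ester series

The source may hold more compounds than are shown below. What is called first, only, known or untested is meant among the compounds shown, and "the series" means these compounds.

Measured so far:
compound 1 `CN(C)C12CC(OC(=O)CCN3CCCCC3)C(C(c3ccccc3)C1)C(c1ccccc1)C2` — 25800 nM
compound 2 `O=C(CCN1CCCCC1)OC1CC2(N3CCCC3)CC(c3ccccc3)C1C(c1ccccc1)C2` — 17800 nM
compound 3 `CN(C)C12CC(OC(=O)CN3CCC(O)CC3)C(C(c3ccccc3)C1)C(c1ccccc1)C2` — 102000 nM

In an ADME assay on L6 cells (Rattus norvegicus) for cytotoxicity (on this read-out lower numbers stand for stronger inhibition and higher numbers for weaker inhibition), compound 1 gives 25800 nM. The change pyrrolidin-1-yl in place of dimethylamino on a saturated ring carbon gives a 1.4-fold lower number from compound 1 to compound 2 (0.16 log units; within the scatter). The change 4-hydroxypiperidin-1-yl in place of (piperidin-1-yl)methyl on a saturated chain carbon bound to a carbonyl carbon gives a 4.0-fold higher number from compound 1 to compound 3 (0.60 log units; beyond the scatter), the highest number of the three.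

Compound 4 `O=C(CN1CCC(O)CC1)OC1CC2(N3CCCC3)CC(c3ccccc3)C1C(c1ccccc1)C2` is not yet measured. It differs from compound 3 by pyrrolidin-1-yl in place of dimethylamino on a saturated ring carbon. This is the same kind of change as from compound 1 to compound 2, though the ring atom that bears the ester group carries a (((4-hydroxypiperidin-1-yl)methyl)carbonyl)oxy group here rather than a ((2-(piperidin-1-yl)ethyl)carbonyl)oxy group. Because a 1.4-fold lower number from compound 1 to compound 2 (0.16 log units; within the scatter) lay within the scatter, compound 4 is expected to show a 1.2-fold lower number from compound 3 to compound 4 (0.08 log units; within the scatter). Compound 4 is thus estimated at 85000 nM, between 40000 nM and 200000 nM.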

Compound 4, half-maximal inhibitory concentration: 93400 nM
Compound 4: middle estimate off by 1.1-fold (0.04 log units), on the low side, and the stated range covers the measured number.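

Pyrrolidin-1-yl in place of dimethylamino on a saturated ring carbon stays a small step on the second ester side chain in this assay, with a 1.1-fold lower number from compound 3 to compound 4 (0.04 log units; within the scatter): the same change on two cores in this assay, a 1.4-fold lower number (0.16 log units; within the scatter) from compound 1 to compound 2 and a 1.1-fold lower number (0.04 log units; within the scatter) from compound 3 to compound 4, 1.3-fold (0.12 log units) apart, within the scatter of two such steps

The change to 4-hydroxypiperidin-1-yl in place of (piperidin-1-yl)methyl also carries over to the core of compound 2, with a 5.2-fold higher number from compound 2 to compound 4 (0.72 log units; beyond the scatter): the same change on two cores in this assay, a 4.0-fold higher number (0.60 log units; beyond the scatter) from compound 1 to compound 3 and a 5.2-fold higher number (0.72 log units; beyond the scatter) from compound 2 to compound 4, 1.3-fold (0.12 log units) apart, within the scatter of two such steps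

These agreements rest on two cores only and show that both steps carried over within these four compounds, not that they would hold on any other core.

Open, from the compounds shown here alone, is whether a morpholin-4-yl group on the saturated ring carbon would fit the same picture. The compounds shown also do not separate the hydroxy group from the chain change, and a longer chain bearing 4-hydroxypiperidin-1-yl would be untested ground.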